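This account rests on a few compounds, and the source may have more. Where it says the series, first, only, none or still open, it means among the compounds named here.

Three compounds carrying the same core, joined through a four-carbon chain to a second aromatic ring bearing a carboxylic acid, have been measured in an assay on HEK293 cells for positive allosteric modulation of metabotropic glutamate receptor 3 (Rattus norvegicus), read by thallium flux, with a stated time of 2.5 min; on this read-out lower numbers stand for smaller maximal responses and higher numbers for larger maximal responses. Compound 1 `Cc1c(OCCCCOc2ccc(C(=O)O)cc2Cl)ccc(C(=O)CC(C)C)c1O` gives 62.9%, compound 2 `Cc1c(OCCCCOc2ccccc2C(=O)O)ccc(C(=O)CC(C)C)c1C` gives 30.7%, and compound 3 `Cc1cc(OCCCCOc2ccc(C(=O)CC(C)C)c(O)c2C)ccc1C(=O)O` gives 41.9%. Compound 3 therefore stands second of the three: its number lies above that of compound 2 by more than the scatter, and below that of compound 1 by a number 21 percentage points lower from compound 1 to compound 3 (beyond the scatter), a modest step that came from exchanging the group on the chain oxygen.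

Compound 4 `Cc1c(OCCCCOc2ccccc2C(=O)O)ccc(C(=O)CC(C)C)c1O` is not yet measured. It differs from compound 3 only at that same chain oxygen: 2-carboxyphenyl in place of 4-carboxy-3-methylphenyl on an oxygen on a saturated carbon. Among the measured compounds shown here, no measured step covers this exact exchange. For the measured compounds named here, the one step that does touch the group on the chain oxygen, a number 21 percentage points lower from compound 1 to compound 3 (beyond the scatter), shows that changes there can move the maximal response by a modest amount. Compound 2 carries the same 2-carboxyphenyl on the chain oxygen, though on a different core, and its value is the lowest of the three. The step for compound 4 is therefore expected to be downward, a number 8.9 percentage points lower from compound 3 to compound 4 (within the scatter), and compound 4 is estimated at 33%, within a range from 18% to 50%.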

Compound 4, largest response reached (reported as percent of maximum), in percent of the reference or control that the assay uses: 28.1%
Compound 4: the middle estimate sits 4.9 percentage points above what was measured; the range from low to high includes it.
By their numbers in this assay, from the lowest: compounds 4 and 2 (each within the scatter of the next); then compound 3; then compound 1.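

Among the compounds sharing the core of compound 1, the 2-carboxyphenyl group gives the lowest maximal response in this assay: the exchange on the chain oxygen gives a number 13.8 percentage points lower from compound 3 to compound 4 (beyond the scatter) and a number 34.8 percentage points lower from compound 1 to compound 4 (beyond the scatter). This shows that the group on the chain oxygen matters with the core held constant, which compound 2 could not show on its different core. With 2-carboxyphenyl in place, hydroxy in place of methyl on an aromatic carbon gives a number 2.6 percentage points lower from compound 2 to compound 4 (within the scatter), so this core exchange has no effect that can be told from the scatter, and nothing available explains these results.

Going by these compounds, it remains open whether the hydroxy and methyl cores would also match when carrying 4-carboxy-2-chlorophenyl or 4-carboxy-3-methylphenyl. On these data alone, the effect of a primary amide in place of the carboxylic acid, or of a longer chain, also remains unknown.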